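The compounds below may be only part of what the source reports. "The series", "measured", "known", "first", "only" and "open" are said of these compounds alone.

Measured compounds:
Compound 1 `O=c1cc(CSC(=S)N2CCCCC2)oc2cc(Cl)ccc12` gives > 25000 nM in a functional assay on HeLa cells (Homo sapiens) for antiproliferative activity, read by MTT assay, with a stated time of 72 h (on this read-out lower numbers stand for stronger inhibition and higher numbers for weaker inhibition), which is a limit of the assay rather than a number.
Compound 2 `O=c1cc(CSC(=S)N2CCCCC2)oc2ccccc12` gives > 25000 nM in this assay, again a limit.
Compound 3 `CC(C)N(C(=S)SCc1coc2ccccc2c1=O)C(C)C` gives > 30000 nM in this assay, also a limit.

From compound 2 to compound 1 the change is chloro in place of hydrogen on an aromatic carbon. The step that the two limits leave unreadable from compound 2 to compound 1 cannot be read because both ends sit at the limit of > 25000 nM in this assay, at which 2 of the 3 values shown sit. Compound 3 differs from compound 2 in its core; the difference between the two cores is not broken down here, and compound 3 sits at the limit of > 30000 nM in this assay, at which 1 of the 3 values shown sits.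

Compound 4 `CC(C)N(C(=S)SCc1coc2cc(Cl)ccc2c1=O)C(C)C` is not yet measured. From compound 3 to compound 4 the change is chloro in place of hydrogen on an aromatic carbon, the same change as from compound 2 to compound 1, at the same place. Among the compounds with values here, the only precedent for this change is the unreadable step that the two limits leave unreadable from compound 2 to compound 1, so no size can be taken from it. Compound 4 is expected to give 40000 nM in this assay, likely between 15000 nM and 120000 nM. The expected step is a step that the limit leaves unreadable from compound 3 to compound 4, resting only on the step that the two limits leave unreadable from compound 2 to compound 1 having shown no readable gain.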

Compound 4, half-maximal inhibitory concentration: > 25000 nM
Compound 4 was reported as a limit (the forecaster's own chance of this, stated with the estimate: 85%); the middle value does not contradict the limit.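

Compound 3 and compound 4 both sit at limits of the assay in this assay, and the step between them, chloro in place of hydrogen on an aromatic carbon, cannot be read. The compounds shown leave open whether this change alters the read-out at all in either pair, compound 2 and compound 1 or compound 3 and compound 4, and where any of the four compounds would fall as an actual number in this assay.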